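This account rests on a few compounds, and the source may have more. Where it says the series, first, only, none or still open, it means among the compounds named here.

Measured so far in an ADME assay on HepG2 2.2.15 cells (Homo sapiens) for cytotoxicity; on this read-out lower numbers stand for higher toxicity in this test and higher numbers for lower toxicity in this test:
- compound 1 `O=C(Nc1ncc(Cc2ccc(Br)cc2)s1)c1ccc2ccccc2c1`: > 50000 nM, an assay limit, not a number
- compound 2 `CC(C)(C)OC(=O)Nc1ncc(C(Oc2ccc(Br)cc2)c2ccc(Cl)cc2)s1`: > 50000 nM, likewise an assay limit
- compound 3 `O=C(Nc1ncc(C(Oc2ccc3cc(Br)ccc3c2)c2ccc(Cl)cc2)s1)C1CC1`: "not toxic" (no number reported)

Compound 3 stands without a single number in this assay; the other two values are limits, and the only anchor in the set is the limit of > 50000 nM in this assay, at which 2 of the 3 values shown sit. Compound 4 `O=C(Nc1ncc(C(Oc2ccc3cc(Br)ccc3c2)c2ccc(Cl)cc2)s1)c1ccc(Cl)nc1` differs from compound 3 by 6-chloropyridin-3-yl in place of cyclopropyl on a carbonyl carbon. Among the compounds with values here, no step between measured compounds exists to size the change; given that every value so far sits at or above the assay ceiling, no shift beyond the scatter is expected in this assay, and compound 4 is expected to remain non-toxic. For compound 4 in this assay the estimate is 50000 nM, between 20000 nM and 100000 nM, most likely reported again only as a limit.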

Compound 4, half-maximal cytotoxic concentration: "not toxic" (no number reported)
Nothing numeric was reported for compound 4; no gap can be computed for the estimate.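

Within the data shown here, compound 3 and compound 4 both carry "not toxic" with no number, and no step between them can be read. The compounds shown leave open at what concentration any of them turns toxic in this assay, with one anchor only: the limit of > 50000 nM in this assay, at which 2 of the 4 values shown sit.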